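A few compounds are considered here, and "the series" means these few. Any claim that something is new, unique, unknown or untested is made for them only; others in the source may bear on it.

Compound 1 `C[C@@H](Nc1c(C(N)=O)cnc2ccc(-c3cccnc3)cc12)c1ccc(Cl)cc1`: in an assay on HT-29 cells for inhibition of Serine-protein kinase ATM (Homo sapiens), read by fluorescence, with a stated time of 1 h (on this read-out lower numbers stand for stronger inhibition and higher numbers for weaker inhibition), compound 1 gives 109 nM.
Compound 2 `CCC(CC)CNc1c(C(N)=O)cnc2ccc(-c3cccnc3)cc12`: in this assay compound 2 gives 73 nM.
Compound 3 `NC(=O)c1cnc2ccc(-c3cccnc3)cc2c1NC1CCCC1`: in this assay compound 3 gives 137 nM.

Compound 3 has the highest of the three numbers, yet the steps of a 1.3-fold higher number from compound 1 to compound 3 (0.10 log units; within the scatter) and a 1.9-fold higher number from compound 2 to compound 3 (0.27 log units; within the scatter) are within the scatter, as is a 1.5-fold lower number from compound 1 to compound 2 (0.17 log units; within the scatter), so the three compounds cannot be ordered. Compound 4 `NC(=O)c1cnc2ccc(-c3cccnc3)cc2c1SC1CCCC1` differs from compound 3 by cyclopentylsulfanyl in place of cyclopentylamino on an aromatic carbon. Going by the values given here, none of the measured steps bears directly on this change: each of them swaps the group carried on the nitrogen while the nitrogen itself stays, whereas here the nitrogen leaves and with it the hydrogen-bond donor. Those three steps were all small, but they give no guide to this replacement. For compound 4 in this assay a higher number is expected, by a step of a 2.9-fold higher number from compound 3 to compound 4 (0.47 log units; beyond the scatter). Compound 4 is therefore estimated at 400 nM, between 100 nM and 2000 nM.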

Compound 4, half-maximal inhibitory concentration: 9700 nM
Estimate against measurement, compound 4: 24-fold (1.38 log units) below, outside the stated range (above it).
By their numbers in this assay, from the lowest: compounds 2, 1 and 3 (each within the scatter of the next); then compound 4.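

In this assay this position proves far more sensitive to the atom attached to the aromatic carbon than to the group that atom carries: cyclopentylsulfanyl in place of cyclopentylamino gives a 71-fold higher number from compound 3 to compound 4 (1.85 log units; beyond the scatter) while the swaps on the nitrogen all stayed within the scatter. Cyclopentylsulfanyl in place of (2-ethylbutyl)amino likewise gives a 130-fold higher number from compound 2 to compound 4 (2.12 log units; beyond the scatter) as a large step. No measurement shown accounts for these steps.

The compounds shown leave open whether cyclopentyloxy or cyclopentyl(methyl)amino on this carbon would track cyclopentylamino or cyclopentylsulfanyl, which would separate the sulfur from the loss of the amine hydrogen.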